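A Methoxy Group Added to a Cinnamate Ester

The source may hold more compounds than are shown below. What is called first, only, known or untested is meant among the compounds shown, and "the series" means these compounds.

Compound 1 `CC(=O)O[C@@H]1C=CC(=O)O[C@@H]1[C@@H](COC(=O)c1ccc([N+](=O)[O-])cc1)OC(C)=O` and compound 2 `O=C1C=C[C@@H](OCc2ccccc2)[C@@H]([C@@H](COC(=O)/C=C/c2ccccc2)OCc2ccccc2)O1` share a common core. In a functional assay on A549 cells (Homo sapiens) for antiproliferative activity, read by MTT assay, with a stated time of 6 days (on this read-out higher numbers stand for weaker inhibition and lower numbers for stronger inhibition), compound 1 gives 8640 nM, and compound 2 gives 13300 nM, the higher of the two numbers shown, though its gap to compound 1 lies within the scatter. Compound 3 `COc1ccc(/C=C/C(=O)OC[C@@H](OCc2ccccc2)[C@H]2OC(=O)C=C[C@H]2OCc2ccccc2)cc1` differs from compound 2 by methoxy in place of hydrogen on an aromatic carbon. For the measured compounds named here, no measured step of this kind is available, so in this assay no change beyond the scatter is expected in either direction. Compound 3 is therefore expected to give 12000 nM, between 5000 nM and 30000 nM. The expected step is a 1.1-fold lower number from compound 2 to compound 3 (0.04 log units; within the scatter).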

Compound 3, half-maximal inhibitory concentration: 4250 nM
Compound 3: the middle estimate sits 2.8-fold (0.45 log units) above what was measured; the measured number lies below the stated range.
By their numbers in this assay, from the lowest: compound 3; then compounds 1 and 2 (each within the scatter of the next).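

In this assay the change from phenyl to 4-methoxyphenyl gives a 3.1-fold lower number from compound 2 to compound 3 (0.50 log units; beyond the scatter) and this modest step lies beyond the scatter. For the compounds shown here, it is the first step here between compounds that differ in one place, and it shows that the number responds to a substituent at this aromatic carbon. Nothing measured here gives a reason for the step. The compounds shown leave open whether this response is particular to methoxy or would also appear with an amine, a chlorine or a longer ether chain at the same carbon.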